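Fluorinated stilbenes: shifting fluoro groups around the rings

A few compounds are considered here, and "the series" means these few. Any claim that something is new, unique, unknown or untested is made for them only; others in the source may bear on it.

Measured so far:
compound 1 `Fc1ccccc1/C=C/c1ccccc1F` 4300 nM
compound 2 `Fc1ccc(F)c(/C=C/c2ccccc2F)c1` 5900 nM
compound 3 `Fc1cccc(/C=C/c2ccc(F)c(F)c2)c1` 5000 nM

All three were run in an assay on HepG2 cells for activation of nuclear factor erythroid 2-related factor 2 (Homo sapiens), read by a luciferase reporter, with a stated time of 5 h; a lower number here means that less compound is needed, a higher number that more compound is needed for the effect. Compound 2 and compound 3 hold the same atoms joined differently; the difference between the two cores is not broken down here. Removing one fluoro, (hydrogen in place of fluoro on an aromatic carbon), gave a 1.4-fold lower number from compound 2 to compound 1 (0.14 log units; within the scatter).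

Compound 4 `Fc1cccc(/C=C/c2cccc(F)c2)c1` is not yet measured. It differs from compound 3 by hydrogen in place of fluoro on an aromatic carbon. This is the same kind of change as from compound 2 to compound 1, but not the same: there the leaving fluoro sat meta to the group of 9 heavy atoms and para to a fluoro group, here it sits ortho to a fluoro group and para to the group of 9 heavy atoms.

Resting on the step of a 1.4-fold lower number from compound 2 to compound 1 (0.14 log units; within the scatter), a step of a 1.3-fold lower number from compound 3 to compound 4 (0.12 log units; within the scatter) is expected from compound 3 to compound 4. Compound 4 is estimated at 3800 nM, between 1800 nM and 8000 nM.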

Compound 4, half-maximal effective concentration: 1000 nM
Beside the measured number, compound 4's estimate is 3.8-fold (0.58 log units) above it; the whole stated range lies above it.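

In this assay, replacing with hydrogen the fluoro that sits ortho to a fluoro group and para to a group of 9 heavy atoms gave a 5.0-fold lower number from compound 3 to compound 4 (0.70 log units; beyond the scatter). Hydrogen in place of fluoro on an aromatic carbon therefore does not carry over between these two cores as one fixed step: the same change on two cores in this assay, a 1.4-fold lower number (0.14 log units; within the scatter) from compound 2 to compound 1 and a 5.0-fold lower number (0.70 log units; beyond the scatter) from compound 3 to compound 4, 3.6-fold (0.56 log units) apart, beyond the scatter of two such steps Two pairs do not show whether the gap follows the place of the leaving fluoro or the rest of the core, as both differ together.

Only fluoro and hydrogen appear on the rings here. Open, as far as these compounds go, are how a hydroxyl, a methoxy or an amine at that same place would read in this assay, and what removing the remaining fluoro groups of compound 4 would do.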